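Compound 3 to compound 4: chloro replaces methyl

The source may hold more compounds than are shown below. What is called first, only, known or untested is meant among the compounds shown, and "the series" means these compounds.

Compound 1 `CC(C)(C)c1cc(OC(=O)c2ccc(Cl)cc2Cl)ccc1O`: 0.167 h
Compound 2 `CC(C)(C)c1cc(OC(=O)c2ccco2)ccc1O`: < 0.25 h (a limit)
Compound 3 `Cc1ccc(C(=O)Oc2ccc(O)c(C(C)(C)C)c2)cc1`: < 0.25 h (a limit)

These values come from an ADME assay on a cell-free system (serum) for metabolic stability; on this read-out higher numbers stand for a longer-lived compound and lower numbers for a shorter-lived compound. Compound 3 stands only at a limit of < 0.25 h and has no number of its own. The same holds for compound 2 through (the limit of < 0.25 h in this assay, at which 2 of the 3 values shown sit). Compound 4 `CC(C)(C)c1cc(OC(=O)c2ccc(Cl)cc2)ccc1O` carries chloro in place of methyl on an aromatic carbon on the ring, turning 4-methylphenyl into 4-chlorophenyl. Within the data shown here, the one measured step that bears on this is a step that the two limits leave unreadable from compound 2 to compound 3 and it gives no size to carry over. Among the measured compounds shown here, compound 1 supplies the only number, 0.167 h in this assay. No step beyond the scatter is therefore expected, and the estimated change is a step that the limit leaves unreadable from compound 3 to compound 4 in this account. For compound 4 the expected half-life is 0.17 h with an estimated range from 0.08 h to 0.3 h.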

Compound 4, half-life: < 0.25 h
Compound 4: a limit, no number; the forecaster's own chance of this, stated with the estimate: 60%; the middle value is on the limit's open side.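

In this assay compound 4 gives < 0.25 h, a limit and not a number. Among these compounds, no step from compound 1, compound 2 or compound 3 to compound 4 can be read. The compounds shown leave open whether chloro in place of methyl changes the half-life at all.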